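Cytotoxicity of a Nucleoside Analogue Series on MOLT-3 Cells

This account rests on a few compounds, and the source may have more. Where it says the series, first, only, none or still open, it means among the compounds named here.

Compound 1 `CC(C)CSc1nc(N)nc2c1ncn2/C=C1/CC1(CO)CO`: "not determined" (no result reported)
Compound 2 `CCCNc1nc(N)nc2c1ncn2/C=C1/CC1(CO)CO`: "not determined" (no result reported)
Compound 3 `CCCCCCCCSc1nc(N)nc2c1ncn2/C=C1/CC1(CO)CO`: > 20000 nM

Three compounds sharing one core were examined in an ADME assay on MOLT-3 cells (Homo sapiens) for cytotoxicity, with a stated time of 7 days; on this read-out lower numbers stand for higher toxicity in this test and higher numbers for lower toxicity in this test. Compound 1 `CC(C)CSc1nc(N)nc2c1ncn2/C=C1/CC1(CO)CO` stands without a number of its own in this assay, where its entry reads "not determined" (no result reported). Compound 2 `CCCNc1nc(N)nc2c1ncn2/C=C1/CC1(CO)CO` likewise has no result in this assay, shown as "not determined" (no result reported). Compound 3 `CCCCCCCCSc1nc(N)nc2c1ncn2/C=C1/CC1(CO)CO` is the only one with an entry that is not simply absent: in this assay compound 3 reaches > 20000 nM, which is a limit of the assay and not a number. So of the three entries one is a limit and two carry no result, and compound 1 cannot be placed on a scale at all; the only reference is the limit of > 20000 nM in this assay, at which 1 of the 3 values shown sits.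

Compound 4 `CCCCCOc1nc(N)nc2c1ncn2/C=C1/CC1(CO)CO` differs from compound 1 by pentyloxy in place of isobutylsulfanyl on an aromatic carbon. For the measured compounds named here, no step between measured compounds is available to size such a change, and the lone limit of compound 3 suggests low toxicity across this core. Compound 4 is therefore expected to show 20000 nM, with a range from 8000 nM to 60000 nM, most likely reported as a limit.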

Compound 4, half-maximal cytotoxic concentration: > 20000 nM
Compound 4 was reported as a limit (the forecaster's own chance of this, stated with the estimate: 70%); the middle value sits exactly at the limit.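

For the compounds shown here, compound 3 and compound 4 are both reported as limits in this assay and not as numbers, so no step between them can be read. The compounds shown leave open whether any chain on the shared core gives a measurable cytotoxic concentration: the limit of > 20000 nM in this assay, at which 2 of the 4 values shown sit.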